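Carboxyfuran in place of oxazole on the chlorophenyl arm

A few compounds are considered here, and "the series" means these few. Any claim that something is new, unique, unknown or untested is made for them only; others in the source may bear on it.

Compound 3 `Cn1nc2c(=O)n(CC3(O)CCN(Cc4ccc(-c5ncco5)cc4Cl)CC3)cnc2c1-c1ccc(CN)cc1` gives 1120 nM in an assay on isolated protein for inhibition of ubiquitin carboxyl-terminal hydrolase 7 (Homo sapiens), with stated times of 30 min and 2 h (on this read-out lower numbers stand for stronger inhibition and higher numbers for weaker inhibition), and stands highest of the three measured numbers. Compound 1 `Cn1nc2c(=O)n(CC3(O)CCN(Cc4ccc(-c5n[nH]c(=O)o5)cc4Cl)CC3)cnc2c1-c1ccc(CN)cc1` gives 171 nM in this assay, and compound 2 `Cn1nc2c(=O)n(CC3(O)CCN(Cc4ccc(-c5ccncc5)cc4Cl)CC3)cnc2c1-c1ccc(CN)cc1` gives 257 nM. The two measured steps that lead to compound 3 both run upward: a 6.5-fold higher number from compound 1 to compound 3 (0.82 log units; beyond the scatter) and a 4.4-fold higher number from compound 2 to compound 3 (0.64 log units; beyond the scatter). Between compound 1 and compound 2 the difference is a 1.5-fold higher number from compound 1 to compound 2 (0.18 log units; within the scatter).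

Compound 4 `Cn1nc2c(=O)n(CC3(O)CCN(Cc4ccc(-c5ccc(C(=O)O)o5)cc4Cl)CC3)cnc2c1-c1ccc(CN)cc1` carries the change (5-carboxyfuran-2-yl in place of 1,3-oxazol-2-yl on an aromatic carbon). Going by the values given here, both known steps bear on this site and show that replacing the oxazole with another aromatic group has so far brought lower numbers; no step shows a carboxylic acid at this position, so the carboxyl itself is unsupported. The expectation in this assay is therefore a step back toward the level of compound 1 and compound 2, of modest size and downward, estimated as a 2.2-fold lower number from compound 3 to compound 4 (0.35 log units; beyond the scatter). The estimated value for compound 4 is 500 nM, with a range from 150 nM to 1600 nM.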

Compound 4, half-maximal inhibitory concentration: 753 nM
For compound 4 the middle estimate is 1.5-fold (0.18 log units) below the measured one, and the stated range covers the measured number.
By their numbers in this assay, from the lowest: compounds 1 and 2 (each within the scatter of the next); then compounds 4 and 3 (each within the scatter of the next).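

In this assay, the 5-carboxyfuran-2-yl group cannot be told apart from the 1,3-oxazol-2-yl group (a 1.5-fold lower number from compound 3 to compound 4 (0.17 log units; within the scatter)), so the larger group, with a hydrogen-bond donor that the oxazole lacks, brings no step beyond the scatter at this position. The carboxyfuran still stays short of the level set by the pyridin-4-yl group (a 2.9-fold higher number from compound 2 to compound 4 (0.47 log units; beyond the scatter)) and by the five-membered ring with three hetero atoms (a 4.4-fold higher number from compound 1 to compound 4 (0.64 log units; beyond the scatter)). Nothing on hand accounts for any of these steps.

The compounds shown leave open how much of the value of compound 4 belongs to the furan ring and how much to the carboxylic acid. An unsubstituted furan-2-yl group or a methyl ester at the same place would separate the two.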